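Methoxy in place of methyl: estimate for compound 3

The source may hold more compounds than are shown below. What is called first, only, known or untested is meant among the compounds shown, and "the series" means these compounds.

Measured compounds:
Compound 1 `O=C(Nc1cnn(-c2ccccc2)c1)c1cccc(NS(=O)(=O)c2ccc(Cl)cc2)c1`: 3130 nM in a functional assay on MCF7 cells (Homo sapiens) for inhibition, read by MTT assay, with a stated time of 48 h; a higher number here means a weaker inhibitor, a lower number a stronger inhibitor
Compound 2 `Cc1ccc(-n2cc(NC(=O)c3cccc(NS(=O)(=O)c4ccc(Cl)cc4)c3)cn2)cc1`: 1080 nM in this assay

Compound 2 holds the lowest of the two numbers in this assay; the nearest is compound 1, and the step of a 2.9-fold lower number from compound 1 to compound 2 (0.46 log units; beyond the scatter) is beyond the scatter. Going by the values given here, that step, methyl in place of hydrogen on an aromatic carbon, is the only measured step.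

Compound 3 `COc1ccc(-n2cc(NC(=O)c3cccc(NS(=O)(=O)c4ccc(Cl)cc4)c3)cn2)cc1` differs from compound 2 by methoxy in place of methyl on an aromatic carbon. Among the compounds with values here, no measured step exchanges methyl for methoxy, so the one step that bears on it only indirectly is a 2.9-fold lower number from compound 1 to compound 2 (0.46 log units; beyond the scatter), which shows that substitution at this aromatic carbon lowered the number. On that footing compound 3 is expected to give a number close to that of compound 2, with the estimated step of a 1.0-fold higher number from compound 2 to compound 3 (0.01 log units; within the scatter) lying within the scatter. The estimate for compound 3 in this assay is 1100 nM, with a range from 450 nM to 2800 nM.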

Compound 3, half-maximal inhibitory concentration: 8720 nM
The estimate for compound 3 lay 7.9-fold (0.90 log units) below the measured number; measured number above the stated range.
By their numbers in this assay, from the lowest: compound 2; then compound 1; then compound 3.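

On the aromatic carbon para to a large group, 4-methylphenyl to 4-methoxyphenyl gives an 8.1-fold higher number from compound 2 to compound 3 (0.91 log units; beyond the scatter) in this assay, so this position is sensitive to the exchange of one small group for another. Set against hydrogen, the two groups move the number in opposite directions: methyl gives a 2.9-fold lower number from compound 1 to compound 2 (0.46 log units; beyond the scatter) and methoxy gives a 2.8-fold higher number from compound 1 to compound 3 (0.44 log units; beyond the scatter), so substitution at this carbon does not lower the number as such. Nothing available accounts for this split between methyl and methoxy.

Going by these compounds, whether an amine, a hydroxyl or a longer chain such as ethoxy at this carbon would go with methyl or with methoxy stays open. The three compounds also leave open whether the same split would hold with a different group elsewhere on the shared core.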